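The source may hold more compounds than are shown below. What is called first, only, known or untested is meant among the compounds shown, and "the series" means these compounds.

Measured so far:
- compound 1, `COc1cc2nc(Nc3ccc(C#N)cc3)nc(Nc3c(C)cc(/C=C/C#N)cc3C)c2cc1OC`, 10200 nM
- compound 2, `COc1cc2nc([S+]([O-])CC(=O)Nc3ccc([N+](=O)[O-])cc3)nc(Nc3c(C)cc(/C=C/C#N)cc3C)c2cc1OC`, 189000 nM
- compound 3, `COc1cc2nc([S+]([O-])CC(=O)Nc3cccc(Cl)c3)nc(Nc3c(Cl)cc(/C=C/C#N)cc3Cl)c2cc1OC`, 68900 nM

All three were tested in an ADME assay on MT4 cells (Homo sapiens) for cytotoxicity, read by MTT assay, with a stated time of 5 days; on this read-out higher numbers stand for lower toxicity in this test and lower numbers for higher toxicity in this test. Compound 1 gives 10200 nM, compound 2 gives 189000 nM and compound 3 gives 68900 nM. Compound 3 thus stands second highest of the three numbers: compound 2 lies above it by a margin beyond the scatter, and compound 1 lies well below it, also beyond the scatter.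

Compound 4, `COc1ccccc1NC(=O)C[S+]([O-])c1nc(Nc2c(Cl)cc(/C=C/C#N)cc2Cl)c2cc(OC)c(OC)cc2n1`, has not yet been measured in this assay. It differs from compound 3 in one place: 2-methoxyphenyl in place of 3-chlorophenyl on an amide-type nitrogen. Going by the values given here, no pair of measured compounds differs in this way, so there is no measured step to lean on. Both compound 2 and compound 3 carry the same sulfoxide-linked acetamide arm with different aryl groups on the amide nitrogen, and both sit far above compound 1; compound 4 keeps that arm. The step from compound 3 to compound 4 is therefore expected to be small, a 1.1-fold higher number from compound 3 to compound 4 (0.04 log units; within the scatter), with no direction beyond the scatter. Compound 4 is estimated at 75000 nM, between 25000 nM and 220000 nM.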

Compound 4, half-maximal cytotoxic concentration: > 204000 nM
Compound 4: only a limit was reported; the forecaster's own chance of this, stated with the estimate: 15%; at least 2.7-fold (0.43 log units) between middle value and limit.
By their numbers in this assay, from the lowest: compound 1; then compound 3; then compound 2. At a limit, above all of these: compound 4.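

In this assay, the aryl group on the amide-type nitrogen proves able to move the number on its own: 2-methoxyphenyl in place of 3-chlorophenyl gives an at least 2.9-fold higher number from compound 3 to compound 4 (0.47 log units; beyond the scatter). Going by these compounds alone, the earlier compounds offered no pair differing in one place, so this is the first measured step at this position, and it points towards lower toxicity in this test. The reading for compound 4 is a limit and not a number: the limit of > 204000 nM in this assay, at which 1 of the 4 values shown sits.

On these data alone, how far the step reaches stays open, as only its lower end can be read. Also open, as far as these compounds go, is whether the methoxy group or the loss of the chlorine carries the step, and how an unsubstituted phenyl, or an aryl group bearing an amine or a carboxylic acid, would read on the same nitrogen.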